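A few compounds are considered here, and "the series" means these few. Any claim that something is new, unique, unknown or untested is made for them only; others in the source may bear on it.

Within the data shown here, compound 2 `O=C(Nc1cccc(-n2cc(-c3ccncc3)c(-c3cc(O)cc(Cl)c3)n2)c1)Nc1ccc(Cl)c(C(F)(F)F)c1` gives 45% in a functional assay on NCI-H322M cells (Homo sapiens) for inhibition, read by sulforhodamine B assay, with a stated time of 48 h, tested at 10 uM (a higher number here means a weaker effect of the compound at the concentration tested, a lower number a stronger effect), the lower of the two numbers measured so far, while compound 1 `COc1cc(Cl)cc(-c2nn(-c3cccc(NC(=O)c4ccc(Cl)c(Cl)c4)c3)cc2-c2ccncc2)c1` gives 84.6% in this assay , a gap that lies beyond the usual scatter. Compound 3 `O=C(Nc1cccc(-n2cc(-c3ccncc3)c(-c3cc(O)cc(Cl)c3)n2)c1)Nc1ccc(Cl)c(Cl)c1` differs from compound 2 in a single place: chloro in place of trifluoromethyl on an aromatic carbon. Among the measured compounds shown here, no pair of measured compounds shows what this swap does here, so the expected step, a number 3 percentage points higher from compound 2 to compound 3 (within the scatter), is small and probably within the scatter. Compound 3 is therefore estimated to give 48% in this assay , with a likely range from 30% to 66%.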

Compound 3, a percentage reported as activity, at one concentration (the size of the read-out at that concentration, not a potency): 19.5%
Compound 3: middle estimate off by 28.5 percentage points, on the high side; the measured number lies below the stated range.
By their numbers in this assay, from the lowest: compound 3; then compound 2; then compound 1.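

At this position, ortho to a chloro group and meta to a large group, chloro and trifluoromethyl are not interchangeable: in this assay the swap gives a number 25.5 percentage points lower from compound 2 to compound 3 (beyond the scatter), and a lower number means a stronger effect. Among these compounds, this pair is the first to show that the group of one heavy atom gives the stronger effect here. Nothing given here explains the step. Going by these compounds, how a fluoro, a methyl or a nitrile group would behave at this position stays open, as does whether the swap would act alike on another core.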